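Acetyl in place of amidine on the thioether amine

The compounds below may be only part of what the source reports. "The series", "measured", "known", "first", "only" and "open" are said of these compounds alone.

Compound 1, `CC(C)c1n[nH]c2c(NCc3ccc(-c4ccccn4)cc3)nc(SC(CO)C(C)C)nc12`, gives 980 nM in a functional assay on HT cells (Homo sapiens) for antiproliferative activity, read by fluorescence, with a stated time of 72 h; on this read-out higher numbers stand for weaker inhibition of growth and lower numbers for stronger inhibition of growth.
Compound 2, `CC(C)c1n[nH]c2c(NCc3ccc(-c4ccccn4)cc3)nc(SCCN)nc12`, gives 22 nM in this assay.
Compound 3, `CC(C)c1n[nH]c2c(NCc3ccc(-c4ccccn4)cc3)nc(SCCNC(=N)N)nc12`, gives 390 nM in this assay.

Compound 3 stands second highest of the three numbers: its nearest neighbour is compound 1, a 2.5-fold lower number from compound 1 to compound 3 (0.40 log units; beyond the scatter), and its furthest is compound 2, an 18-fold higher number from compound 2 to compound 3 (1.25 log units; beyond the scatter). Compound 4, `CC(=O)NCCSc1nc(NCc2ccc(-c3ccccn3)cc2)c2[nH]nc(C(C)C)c2n1`, has not yet been measured in this assay. It differs from compound 3 by a group of 3 heavy atoms (2 carbon, 1 oxygen; no ring) in place of a group of 3 heavy atoms (1 carbon, 2 nitrogen; no ring), on an amine nitrogen.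

Within the data shown here, the step that bears most directly on this change is the one from compound 2 to compound 3, where a group was placed on the same amine nitrogen and gave an 18-fold higher number from compound 2 to compound 3 (1.25 log units; beyond the scatter). The step from compound 1 to compound 2, a 45-fold lower number from compound 1 to compound 2 (1.65 log units; beyond the scatter), shows that the free amine gave the lowest number of the set. Compound 4 again carries a substituent on that nitrogen, now the acetyl, so a number near compound 3 or somewhat higher is expected rather than a return toward compound 2. Compound 4 is therefore expected to give 500 nM, within 150 nM to 1800 nM, which is estimated as a 1.3-fold higher number from compound 3 to compound 4 (0.11 log units; within the scatter).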

Compound 4, concentration for 50% growth inhibition: 71 nM
For compound 4 the middle estimate is 7.0-fold (0.85 log units) above the measured one; the measured number lies below the stated range.
By their numbers in this assay, from the lowest: compound 2; then compound 4; then compound 3; then compound 1.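

In this assay, the two groups on the amine nitrogen do not behave alike: acetyl in place of the group in compound 3 shifts the number clearly (a 5.5-fold lower number from compound 3 to compound 4 (0.74 log units; beyond the scatter)), although both groups have the same heavy-atom count, with one double bond outside aromatic rings and no net charge. Acetyl on the amine of compound 2 still raises the number (a 3.2-fold higher number from compound 2 to compound 4 (0.51 log units; beyond the scatter)), but less than the other group does (an 18-fold higher number from compound 2 to compound 3 (1.25 log units; beyond the scatter)), so the size of the rise on that nitrogen depends on the group placed there. The 2-acetamidoethyl group also remains well ahead of 1-(hydroxymethyl)-2-methylpropyl on the sulfur (a 14-fold lower number from compound 1 to compound 4 (1.14 log units; beyond the scatter)), and nothing measured here accounts for any of these steps.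

The compounds shown leave open how a methyl or a methanesulfonyl group on that nitrogen would compare. They also leave open whether the same order holds with a longer chain on the sulfur.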